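Swapping a para-fluoro for a methyl on a benzamide

The compounds below may be only part of what the source reports. "The series", "measured", "known", "first", "only" and "open" are said of these compounds alone.

Measured compounds:
- Compound 1, `Nc1ccccc1NC(=O)c1ccc(COc2ccc(Br)cc2)cc1`: > 32000 nM
- Compound 2, `CCCc1ccc(OCc2ccc(C(=O)Nc3ccccc3N)cc2)cc1`: 3230 nM
- Compound 3, `Nc1ccccc1NC(=O)c1ccc(COc2ccc(F)cc2)cc1`: 3860 nM

Three compounds share one core and differ only in the group on the outer phenoxy ring. In a functional assay on HCT-116 cells (Homo sapiens) for antiproliferative activity, read by CCK-8 assay, with a stated time of 72 h (a lower number here means a stronger inhibitor, a higher number a weaker inhibitor), compound 1 gives only a limit of the assay, > 32000 nM (the limit of > 32000 nM in this assay, at which 1 of the 3 values shown sits). In this assay compound 2 gives 3230 nM and compound 3 gives 3860 nM. Compound 3 thus holds the higher of the two real numbers, but its gap to compound 2, a 1.2-fold higher number from compound 2 to compound 3 (0.08 log units; within the scatter), is within the scatter, so the two cannot be ordered.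

Compound 4, `Cc1ccc(OCc2ccc(C(=O)Nc3ccccc3N)cc2)cc1`, is not yet measured. It differs from compound 3 by methyl in place of fluoro on an aromatic carbon.

Going by the values given here, two measured steps bear on this change. Leaving bromo for propyl gave an at least 9.9-fold lower number from compound 1 to compound 2 (0.99 log units; beyond the scatter) and leaving bromo for fluoro gave an at least 8.2-fold lower number from compound 1 to compound 3 (0.91 log units; beyond the scatter), so both a small halogen and an alkyl chain sit far from the limit of compound 1. Between propyl and fluoro themselves the step of a 1.2-fold higher number from compound 2 to compound 3 (0.08 log units; within the scatter) lies within the scatter. A methyl is a shorter alkyl than propyl, so compound 4 is expected to behave like compound 2 and compound 3, with a step of about a 1.1-fold lower number from compound 3 to compound 4 (0.04 log units; within the scatter), not beyond the scatter.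

Compound 4 is therefore estimated at 3500 nM, within 1200 nM to 10000 nM.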

Compound 4, half-maximal inhibitory concentration: 4860 nM
Beside the measured number, compound 4's estimate is 1.4-fold (0.14 log units) below it; the range from low to high includes it.
By their numbers in this assay, from the lowest: compounds 2, 3 and 4 (each within the scatter of the next). At a limit, above all of these: compound 1.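

Replacing propyl with methyl gives a 1.5-fold higher number from compound 2 to compound 4 (0.18 log units; within the scatter), and replacing fluoro with methyl gives a 1.3-fold higher number from compound 3 to compound 4 (0.10 log units; within the scatter), so in this assay shortening the alkyl chain to a single carbon, or exchanging fluoro for methyl, brings no readable change at this position. Going by these compounds alone, compound 1 remains the one that goes against this pattern, with an at least 6.5-fold lower number from compound 1 to compound 4 (0.81 log units; beyond the scatter), so a third group now sits clearly apart from bromo, and that group is a small alkyl, which the two earlier comparisons with propyl and fluoro could not show on their own. The value of compound 1 is a limit of the assay, not a number, so the true size of these steps from bromo stays unknown: the limit of > 32000 nM in this assay, at which 1 of the 4 values shown sits.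

The compounds shown leave open whether chloro, a second halogen closer to bromo in the series, would follow fluoro or bromo at this position. They also leave open how an amine, a carboxylic acid or a chain longer than propyl would read here, and they do not tell why bromo stands apart.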